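Working notes on a small antiproliferative series

The source may hold more compounds than are shown below. What is called first, only, known or untested is meant among the compounds shown, and "the series" means these compounds.

Measured so far in a functional assay on A549 cells (Homo sapiens) for antiproliferative activity, read by trypan blue exclusion, with a stated time of 24 h; a lower number here means a stronger inhibitor, a higher number a weaker inhibitor:
compound 1 `O=C1NC(=O)/C(=C/c2cn(Cc3ccc(Cl)cc3)c3ccccc23)N1` gives 25400 nM
compound 2 `O=C1NC(=O)/C(=C/c2cn(Cc3ccc(F)cc3)c3ccccc23)N1` gives 27800 nM
compound 3 `O=C1NC(=O)/C(=C/c2cn(Cc3ccccc3)c3ccc(Cl)cc23)N1` gives 29700 nM

Compound 3 holds the largest of the three numbers, but its gaps to compound 2 and to compound 1 are both within the scatter, so the three cannot be told apart. Compound 4 `COc1ccc2c(c1)c(/C=C1\NC(=O)NC1=O)cn2Cc1ccccc1` differs from compound 3 by methoxy in place of chloro on an aromatic carbon. Among the compounds with values here, the only measured step, a 1.1-fold higher number from compound 1 to compound 2 (0.04 log units; within the scatter), concerns a different place and a different swap, and shows nothing beyond the scatter; no measured step touches the position changed here. In this assay no step beyond the scatter is therefore expected for compound 4, and the estimated step is a 1.0-fold higher number from compound 3 to compound 4 (0.00 log units; within the scatter). Compound 4 is expected near 30000 nM, within 12000 nM to 75000 nM.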

Compound 4, half-maximal inhibitory concentration: > 40000 nM
Compound 4: only a limit was reported; the forecaster's own chance of this, stated with the estimate: 10%; at least 1.3-fold (0.12 log units) between middle value and limit.
By their numbers in this assay, from the lowest: compounds 1, 2 and 3 (each within the scatter of the next). At a limit, above all of these: compound 4.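

Compound 4 gives > 40000 nM as a limit of this assay and not a number. Methoxy in place of chloro on this aromatic carbon gives an at least 1.3-fold higher number from compound 3 to compound 4 (0.12 log units; that floor lies within the scatter) and so separates the two compounds by no more than the scatter, while the true size of the change cannot be read. Within the data shown here, this is the first change at this position, and only compound 4 stands at a limit: the limit of > 40000 nM in this assay, at which 1 of the 4 values shown sits.

On these data alone, how far the value of compound 4 lies past that limit remains open. Also open, as far as these compounds go, is how an amine, a carboxylic acid or a longer alkoxy chain on this carbon would read against compound 3.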